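Cytotoxicity limits in the hexanoate series

The source may hold more compounds than are shown below. What is called first, only, known or untested is meant among the compounds shown, and "the series" means these compounds.

Compound 1 `CC(=O)Nc1cccc(-c2ccc(C(=O)N(Cc3cccc(OCCCCCC(=O)O)c3)C(C)C)cc2)c1` gives in an ADME assay on HepG2 cells (Homo sapiens) for cytotoxicity, read by CellTiter-Glo and resazurin assay, with a stated time of 72 h (a lower number here means that less compound is needed, a higher number that more compound is needed for the effect), only the limit > 26000 nM. Compound 2 `CC(C)N(Cc1cccc(OCCCCCC(=O)O)c1)C(=O)c1ccc(-c2cc3ccccc3n2S(=O)(=O)c2ccccc2)cc1` likewise reaches only the limit > 26000 nM in this assay. Compound 3 `CCOC(=O)CCCCCOc1cccc(CN(C(=O)c2ccc(-c3cccc(NC(C)=O)c3)cc2)C(C)C)c1` also sits at the limit > 26000 nM in this assay. The step that the two limits leave unreadable from compound 1 to compound 3 is thus unreadable, as the limit of > 26000 nM in this assay, at which 3 of the 3 values shown sit, shows, and compound 3 stands where every value of the set stands. Compound 4 `CCOC(=O)CCCCCOc1cccc(CN(C(=O)c2ccc(-c3cc(OC)cc(OC)c3)cc2)C(C)C)c1` differs from compound 3 by 3,5-dimethoxyphenyl in place of 3-acetamidophenyl on an aromatic carbon. For the measured compounds named here, no measured step covers this exchange, and the one measured step runs between two limits, so only the limit itself bears on the expectation. In this assay the step that the limit leaves unreadable from compound 3 to compound 4 is expected to be negligible. Compound 4 is estimated at 30000 nM, with a range from 12000 nM to 80000 nM.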

Compound 4, half-maximal effective concentration: > 26000 nM
Compound 4: a limit, no number; the forecaster's own chance of this, stated with the estimate: 85%; the middle value does not contradict the limit.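

For the compounds shown here, compound 3 and compound 4 both stay at a limit in this assay, so no step between them can be read: the limit of > 26000 nM in this assay, at which 4 of the 4 values shown sit.
The compounds shown leave open at what concentration, if any, a member of this series reaches the half-maximal effect.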